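A few compounds are considered here, and "the series" means these few. Any claim that something is new, unique, unknown or untested is made for them only; others in the source may bear on it.

Series notes.

Compound 1 `O=C(COc1ccc(C(=O)/C=C/c2cccc(Cl)c2)cc1)N[C@H]1CCOC1=O`: 20900 nM.
Compound 2 `O=C1OCC[C@@H]1NC(=S)SCCOc1cccc2ccccc12`: > 64000 nM, a limit of the assay.
Compound 3 `CC(C)c1ccc(NCC(=O)N[C@H]2CCOC2=O)cc1`: > 64000 nM, a limit of the assay.

All three were run in a functional assay on MCF7 cells (Homo sapiens) for antiproliferative activity, read by MTT assay, with a stated time of 72 h; on this read-out lower numbers stand for stronger inhibition and higher numbers for weaker inhibition. Within the data shown here, compound 1 is the only one that returns a number. Compound 2 and compound 3 sit at the limit of > 64000 nM in this assay, at which 2 of the 3 values shown sit, so no comparison with compound 1 can be drawn for either of them. Compound 4 `O=C(COc1ccc(C(=O)/C=C/c2cccc([N+](=O)[O-])c2)cc1)N[C@H]1CCOC1=O` differs from compound 1 in one place: nitro in place of chloro on an aromatic carbon. Among the measured compounds shown here, with no measured step of any kind in this set, the change is expected to leave potency within the scatter of compound 1 or to give at most a modest gain; the expected step is a 1.4-fold lower number from compound 1 to compound 4 (0.14 log units; within the scatter). For compound 4 the estimate in this assay is 15000 nM, ranging from 5000 nM to 45000 nM.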

Compound 4, half-maximal inhibitory concentration: > 64000 nM
Compound 4 gave a limit, no number (the forecaster's own chance of this, stated with the estimate: 15%); middle value at least 4.2-fold (0.63 log units) from the limit.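

In this assay the change from 3-chlorophenyl to 3-nitrophenyl gives an at least 3.0-fold higher number from compound 1 to compound 4 (0.48 log units; beyond the scatter) and so shows that this aromatic position is not indifferent to the group it carries. The value of compound 4 is a limit, so only the direction of the step and its smallest size are fixed. Among these compounds, compound 1 is the only compound with a number: the limit of > 64000 nM in this assay, at which 3 of the 4 values shown sit.

From the compounds shown here alone, whether the chloro can be exchanged at this position for fluoro, methyl or an amine without loss remains open. Also open, going by these compounds, is whether any group there gives a lower number than compound 1.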